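A few compounds are considered here, and "the series" means these few. Any claim that something is new, unique, unknown or untested is made for them only; others in the source may bear on it.

The series shares one core, seen in compound 1 `O=C(CSc1nnc(-c2ccncc2)o1)N/N=C/c1ccccc1[N+](=O)[O-]` and compound 2 `O=C(CSc1nnc(-c2ccncc2)o1)N/N=C/c1cc(Br)ccc1O`. In an ADME assay on NIH3T3 cells (Mus musculus) for cytotoxicity, read by MTT assay, with a stated time of 24 h (a lower number here means a stronger inhibitor, a higher number a weaker inhibitor), compound 1 gives 214000 nM. In this assay compound 2 gives 156000 nM, and the two numbers lie within the usual scatter of each other, so neither compound can be set apart from the other on this read-out. Among the compounds with values here, the only step measured so far, a 1.4-fold lower number from compound 1 to compound 2 (0.14 log units; within the scatter), exchanged the substituent on the carbon with a double bond to nitrogen and moved the number little. Compound 3 `COc1cc(/C=N/NC(=O)CSc2nnc(-c3ccncc3)o2)ccc1O` differs from compound 2 in the same place: 4-hydroxy-3-methoxyphenyl in place of 5-bromo-2-hydroxyphenyl on a carbon with a double bond to nitrogen. That earlier step bears on it directly, because a 1.4-fold lower number from compound 1 to compound 2 (0.14 log units; within the scatter) shows that swapping the group on the carbon with a double bond to nitrogen left the half-maximal inhibitory concentration essentially where it was. Compound 3 is therefore expected to shift by about a 1.2-fold higher number from compound 2 to compound 3 (0.06 log units; within the scatter), a step that stays within the scatter. The half-maximal inhibitory concentration of compound 3 in this assay is estimated at 180000 nM, with a range from 80000 nM to 400000 nM.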

Compound 3, half-maximal inhibitory concentration: 148000 nM
Estimate against measurement, compound 3: 1.2-fold (0.09 log units) above; low and high end bracket the measured number.
By their numbers in this assay, from the lowest: compounds 3, 2 and 1 (each within the scatter of the next).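

In this assay, the step with a 1.1-fold lower number from compound 2 to compound 3 (0.02 log units; within the scatter) and the step with a 1.4-fold lower number from compound 1 to compound 3 (0.16 log units; within the scatter) both stay within the scatter, and the first of them exchanges 5-bromo-2-hydroxyphenyl for 4-hydroxy-3-methoxyphenyl on a carbon with a double bond to nitrogen. With a third group now in this place, all three substituted phenyl groups shown give values within the scatter of one another, so the exchange of bromine for a methoxy group, with the hydroxy group moved, separates these compounds no more than the earlier exchange of the nitro group did. Nothing available explains why these exchanges leave the read-out unmoved.

As far as these compounds go, all three compounds carry a six-membered aromatic ring of carbon at this place, so it remains open whether the values would hold with a simple alkyl chain there, or with an amine or a carboxylic acid on the phenyl ring. The compounds shown also vary only this one place, which leaves open how changes elsewhere in the shared core would read in this assay.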